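This account rests on a few compounds, and the source may have more. Where it says the series, first, only, none or still open, it means among the compounds named here.

Compound 1 `CCCCCCCCC(=O)N1c2ccccc2CCC1C(=O)Nc1ccccc1C(F)(F)F` gives 8330 nM in a functional assay on ACHN cells (Homo sapiens) for cytotoxicity, read by sulforhodamine B assay, with a stated time of 72 h; on this read-out lower numbers stand for stronger inhibition of growth and higher numbers for weaker inhibition of growth. Compound 2 `CCC(=O)N1c2ccccc2CCC1C(=O)Nc1ccccc1C(F)(F)F` shares the core of compound 1, and for compound 2 this assay reports only a limit, > 80000 nM. Going by the values given here, the change between them, (hydrogen in place of hexyl on a saturated chain carbon, two bonds along the chain from a carbonyl carbon), thus produces an at least 9.6-fold higher number from compound 1 to compound 2 (0.98 log units; beyond the scatter), and the only evidence on this step is the limit of > 80000 nM in this assay, at which 1 of the 3 values shown sits. Compound 3 `CCCCCCCCC(=O)N1c2ccccc2CCC1C(=O)Nc1cc(C(F)(F)F)cc(C(F)(F)F)c1` gives 4520 nM in this assay; its value and that of compound 1 lie within the usual scatter of each other, and the difference between the two cores is not broken down here. Compound 4 `CCC(=O)N1c2ccccc2CCC1C(=O)Nc1cc(C(F)(F)F)cc(C(F)(F)F)c1` is not yet measured. It differs from compound 3 by hydrogen in place of hexyl on a saturated chain carbon, two bonds along the chain from a carbonyl carbon, which is the same change as that from compound 1 to compound 2. The step is expected to be about a 13-fold higher number from compound 3 to compound 4 (1.12 log units; beyond the scatter), resting on the step from compound 1 to compound 2 of an at least 9.6-fold higher number from compound 1 to compound 2 (0.98 log units; beyond the scatter) and on the value of compound 3 of 4520 nM. Compound 4 is therefore estimated at 60000 nM, most likely between 20000 nM and 300000 nM, with a fair chance that this assay reports only a limit.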

Compound 4, concentration for 50% growth inhibition: 7720 nM
For compound 4 the middle estimate is 7.8-fold (0.89 log units) above the measured one, outside the stated range (below it).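

In this assay, placing hydrogen where hexyl stood on the core of compound 3 gives a 1.7-fold higher number from compound 3 to compound 4 (0.23 log units; within the scatter), so on this core the change stays within the scatter. The same change therefore does not carry over from one core to the other at the same size, and the step seen on the core of compound 1 cannot simply be transferred to the core of compound 3: the same change on two cores in this assay, an at least 9.6-fold higher number (0.98 log units; beyond the scatter) from compound 1 to compound 2 and a 1.7-fold higher number (0.23 log units; within the scatter) from compound 3 to compound 4, at least 5.6-fold (0.74 log units) apart, beyond the scatter of two such steps. For compound 2 this assay gives only a limit, > 80000 nM, and these four compounds do not show what sets the two steps apart.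

As far as these compounds go, it remains open whether a chain of intermediate length, a longer chain, or a chain ending in an amine or a carboxylic acid would follow the step seen on either core. Also open, from the compounds shown here alone, is whether a further core carrying a single or a double trifluoromethyl substitution would behave like that of compound 1 or that of compound 3.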